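A Methyl Added to the Saturated Chain

This account rests on a few compounds, and the source may have more. Where it says the series, first, only, none or still open, it means among the compounds named here.

In a functional assay on KB cells (Homo sapiens) for cytotoxicity, read by resazurin assay, with a stated time of 3 days (a higher number here means a weaker inhibitor, a lower number a stronger inhibitor), compound 1 `CCCCCCC(=O)NCC(C)(C)CC1=C(O)C(=O)c2ccccc2C1=O` gives 28200 nM and compound 2 `CCCCCCCCCC(=O)NCC(C)(C)CC1=C(O)C(=O)c2ccccc2C1=O` gives 18500 nM, so compound 2 stands within the scatter of compound 1. Compound 3 `CCCCCCCCCCC(=O)NCC(C)(C)CC1=C(O)C(=O)c2ccccc2C1=O` differs from compound 2 by methyl in place of hydrogen on a saturated chain carbon, nine bonds along the chain from a carbonyl carbon. Among the measured compounds shown here, the one measured step bearing on this change is a 1.5-fold lower number from compound 1 to compound 2 (0.18 log units; within the scatter), which put propyl in place of hydrogen on the same chain. On that evidence, no step beyond the scatter is expected in this assay. The estimated step is a 1.1-fold lower number from compound 2 to compound 3 (0.04 log units; within the scatter). Compound 3 is expected at 17000 nM, with an estimated range from 8000 nM to 33000 nM.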

Compound 3, half-maximal inhibitory concentration: 17600 nM
Estimate against measurement, compound 3: 1.0-fold (0.02 log units) below, and the stated range covers the measured number.
By their numbers in this assay, from the lowest: compounds 3, 2 and 1 (each within the scatter of the next).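

In this assay methyl in place of hydrogen on a saturated chain carbon, nine bonds along the chain from a carbonyl carbon, gives a 1.1-fold lower number from compound 2 to compound 3 (0.02 log units; within the scatter) and so stays within the scatter at this position. Extending the same chain further gives a 1.6-fold lower number from compound 1 to compound 3 (0.20 log units; within the scatter) and also stays within the scatter, so a larger extension than the propyl step still separates no compounds. No measurement here accounts for this result.

The compounds shown leave open whether a longer chain, or a chain ending in an amine or a carboxylic acid, would move the number beyond the scatter. They also leave open what a change on the shared core would do.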